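A few compounds are considered here, and "the series" means these few. Any claim that something is new, unique, unknown or untested is made for them only; others in the source may bear on it.

Measured so far:
compound 1 `COC(=O)C(=O)CNC1=CS(=O)(=O)O[C@@]12[C@@H](CO[Si](C)(C)C(C)(C)C)O[C@@H](n1cc(C)c(=O)n(C)c1=O)[C@@H]2O[Si](C)(C)C(C)(C)C`: > 200000 nM
compound 2 `COC(=O)CC(=O)NC1=CS(=O)(=O)O[C@@]12[C@@H](CO[Si](C)(C)C(C)(C)C)O[C@@H](n1cc(C)c(=O)n(C)c1=O)[C@@H]2O[Si](C)(C)C(C)(C)C`: 29000 nM
compound 3 `Cc1cn([C@@H]2O[C@H](CO[Si](C)(C)C(C)(C)C)[C@@]3(OS(=O)(=O)C=C3NCCC(=O)O)[C@H]2O[Si](C)(C)C(C)(C)C)c(=O)n(C)c1=O`: 34000 nM

In a functional assay on HEL cells (Homo sapiens) (a lower number here means that less compound is tolerated, a higher number that more compound is tolerated), compound 1 reaches only the limit of the measurement, (the limit of > 200000 nM in this assay, at which 1 of the 3 values shown sits), and no number is known for it. In this assay compound 2 gives 29000 nM. Compound 3 gives 34000 nM in this assay. The two steps from compound 1 are an at least 6.8-fold lower number from compound 1 to compound 2 (0.83 log units; beyond the scatter) and an at least 5.8-fold lower number from compound 1 to compound 3 (0.76 log units; beyond the scatter), both only bounds since compound 1 sits at the limit. Between the two measured neighbours the step is a 1.2-fold higher number from compound 2 to compound 3 (0.07 log units; within the scatter).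

Compound 4 `Cc1cn([C@@H]2O[C@H](CO[Si](C)(C)C(C)(C)C)[C@@]3(OS(=O)(=O)C=C3NCC(=O)C(=O)O)[C@H]2O[Si](C)(C)C(C)(C)C)c(=O)n(C)c1=O` is not yet measured. It differs from compound 1 as follows: hydrogen in place of methyl on an oxygen next to a carbonyl group. Among the compounds with values here, the nearest measured step is the one to compound 3, which also carries a carboxy group and gave an at least 5.8-fold lower number from compound 1 to compound 3 (0.76 log units; beyond the scatter); compound 2, with a methyl ester, gave an at least 6.8-fold lower number from compound 1 to compound 2 (0.83 log units; beyond the scatter). Both measured changes on this chain lowered the number, so a lower number than the limit of compound 1 is expected for compound 4 too, though the size cannot be fixed since compound 1 has only a limit. Compound 4 is expected to give 80000 nM in this assay, between 25000 nM and 200000 nM. That estimate amounts to a step of an at least 2.5-fold lower number from compound 1 to compound 4 (0.39 log units; beyond the scatter).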

Compound 4, half-maximal cytotoxic concentration: 146000 nM
Beside the measured number, compound 4's estimate is 1.8-fold (0.26 log units) below it, within the range that was stated.
By their numbers in this assay, from the lowest: compounds 2 and 3 (each within the scatter of the next); then compound 4. At a limit, above all of these: compound 1.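

In this assay, the change from methoxycarbonyl to carboxy gives an at least 1.3-fold lower number from compound 1 to compound 4 (0.13 log units; that floor lies within the scatter), so the acid cannot be told apart from the methyl ester, because compound 1 stands at a limit and not at a number: the limit of > 200000 nM in this assay, at which 1 of the 4 values shown sits. With the carboxy group kept, carboxycarbonyl in place of carboxymethyl gives a 4.3-fold higher number from compound 3 to compound 4 (0.63 log units; beyond the scatter), which shows that the chain itself still matters among the acids. The comparison with the malonyl-type amide gives a 5.0-fold higher number from compound 2 to compound 4 (0.70 log units; beyond the scatter), so compound 4 stands apart from compounds 2 and 3, whose values lie within the scatter of each other.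

Going by these compounds, whether the higher number of compound 4 depends on the chain carbonyl alone remains open. Also open, on these data alone, is what a primary amide or a longer chain on this amine nitrogen would give in this assay, or a free hydroxy group in place of the silyl ethers.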